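Swapping the Acetamide Headgroup on a Chemokine Receptor Antagonist

This account rests on a few compounds, and the source may have more. Where it says the series, first, only, none or still open, it means among the compounds named here.

Three analogues sharing one core have been measured in a functional assay on U2OS cells for antagonist activity at C-X-C chemokine receptor type 3 (Homo sapiens), read by beta-arrestin recruitment; a lower number here means a stronger inhibitor, a higher number a weaker inhibitor. Compound 1 `C[C@@H]1CN(c2sc(C(F)(F)F)nc2-c2nc3ccccc3[nH]2)CCN1C(=O)Cn1cnc2cccnc21` gives 31 nM, compound 2 `Cc1ncc(-c2nc(C(F)(F)F)sc2N2CCN(C(=O)Cn3cnc4cccnc43)[C@H](C)C2)cn1` gives 168 nM, and compound 3 `CCOc1ncc(-c2nc(C(F)(F)F)sc2N2CCN(C(=O)Cn3c(=O)oc4ccccc43)[C@H](C)C2)cn1` gives 99 nM. Compound 3 thus sits within the scatter of compound 2 and beyond the scatter from compound 1. Going by the values given here, the only measured step, a 5.4-fold higher number from compound 1 to compound 2 (0.73 log units; beyond the scatter), alters an aromatic group elsewhere on the core. Compound 4 `CCOc1ncc(-c2nc(C(F)(F)F)sc2N2CCN(C(=O)Cn3ccc(C(F)(F)F)n3)[C@H](C)C2)cn1` differs from compound 3 by a group of 9 heavy atoms (4 carbon, 2 nitrogen, 3 fluorine; one five-membered aromatic ring with 2 hetero atoms) in place of a group of 10 heavy atoms (7 carbon, 1 nitrogen, 2 oxygen; one five-membered aromatic ring with 2 hetero atoms, one six-membered aromatic ring of carbon only), on a saturated chain carbon bound to a carbonyl carbon. Among the compounds with values here, no measured step touches that position, so the change carries no clear expectation of direction. A step within the scatter is expected, a 1.2-fold higher number from compound 3 to compound 4 (0.08 log units; within the scatter). Compound 4 is therefore estimated at 120 nM, within a range of 40 nM to 400 nM.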

Compound 4, half-maximal inhibitory concentration: 93 nM
For compound 4 the middle estimate is 1.3-fold (0.11 log units) above the measured one; low and high end bracket the measured number.
By their numbers in this assay, from the lowest: compound 1; then compounds 4, 3 and 2 (each within the scatter of the next).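

At the saturated chain carbon bound to a carbonyl carbon, a 1.1-fold lower number from compound 3 to compound 4 (0.03 log units; within the scatter) shows that in this assay a group with a six-membered carbon ring and a five-membered ring can give way to the single ring of 3-(trifluoromethyl)-1H-pyrazol-1-yl without a change beyond the scatter. This position therefore accepts two quite different groups, at least on the shared core of compound 3 and compound 4. No measurement here explains why these two groups read alike.

Going by these compounds, whether a carboxylic acid or a simple amine at this position would hold the number remains open. So does whether 3-(trifluoromethyl)-1H-pyrazol-1-yl would behave the same alongside the 1H-benzimidazol-2-yl of compound 1.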